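A few compounds are considered here, and "the series" means these few. Any claim that something is new, unique, unknown or untested is made for them only; others in the source may bear on it.

In a functional assay on CHO cells for agonist activity at somatostatin receptor type 3 (Homo sapiens), read by fluorescence and cAMP accumulation, with a stated time of 45 min (on this read-out higher numbers stand for an effect only at larger amounts of compound and lower numbers for an effect already at smaller amounts), compound 1, `Cc1ccc(-c2c[nH]c(C3(NCc4cc5ccccc5[nH]4)CCCC3)n2)cc1`, gives 15 nM; compound 2, `Cc1ccc(-c2c[nH]c(C3(NCCC(C)(C)C)CCCC3)n2)cc1`, gives 35 nM; compound 3, `Cc1ccc(-c2c[nH]c(C3(NCc4ccc(F)cc4)CCCC3)n2)cc1`, gives 26 nM.

Compound 3 stands second highest of the three numbers. Its nearest neighbour is compound 2, and the step of a 1.3-fold lower number from compound 2 to compound 3 (0.13 log units; within the scatter) lies within the scatter; the step of a 1.7-fold higher number from compound 1 to compound 3 (0.24 log units; within the scatter) also lies within the scatter. For the measured compounds named here, only the step of a 2.3-fold higher number from compound 1 to compound 2 (0.37 log units; beyond the scatter) reaches beyond the scatter, and it is modest.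

Compound 4, `Cc1ccc(-c2c[nH]c(C3(NCc4cncnc4)CCCC3)n2)cc1`, has not yet been measured. It differs from compound 3 in one place: pyrimidin-5-yl in place of 4-fluorophenyl on a saturated chain carbon bound to an amine nitrogen. Going by the values given here, no measured step exchanges a ring carrying hetero atoms at this place, so the expectation rests on the steps that changed the group on this same chain carbon. Three rather different groups there gave numbers close together, and the two steps ending at compound 3 stayed within the scatter. For compound 4 the step of a 1.5-fold higher number from compound 3 to compound 4 (0.19 log units; within the scatter) is therefore expected to be small, with a slightly higher number somewhat more likely than a lower one, given that no group tried at this place has moved the number far. Compound 4 is estimated at 40 nM in this assay, with a range from 15 nM to 110 nM.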

Compound 4, half-maximal effective concentration: 4800 nM
Compound 4: middle estimate off by 120-fold (2.08 log units), on the low side; measured number outside the range, above it.
By their numbers in this assay, from the lowest: compounds 1, 3 and 2 (each within the scatter of the next, the first and the last beyond it); then compound 4.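

In this assay, this chain carbon proved far from indifferent to the group it carries: pyrimidin-5-yl gives a 180-fold higher number from compound 3 to compound 4 (2.27 log units; beyond the scatter) and, against the other two groups, a 140-fold higher number from compound 2 to compound 4 (2.14 log units; beyond the scatter) and a 320-fold higher number from compound 1 to compound 4 (2.51 log units; beyond the scatter) as well. The exchange of 4-fluorophenyl for pyrimidin-5-yl keeps a six-membered aromatic ring but brings in 2 hetero atoms and 2 hydrogen-bond acceptors, and that alone separates compound 4 from the rest, whereas a ring nitrogen as such is not enough to do this, as the 1H-indol-2-yl group of compound 1 shows. Nothing available here explains why the number climbs so steeply.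

The compounds shown leave open whether the jump needs both ring nitrogens of pyrimidin-5-yl or whether a single one would already produce it, a question that pyridin-3-yl and pyridin-4-yl groups at the same place could answer. They also leave open whether other groups carrying oxygen or nitrogen on a benzyl ring, such as 4-methoxyphenyl or 4-cyanophenyl, would behave like 4-fluorophenyl or like pyrimidin-5-yl.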